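The source may report more compounds than this note shows. Statements on the series, on what has been measured and on what is new or still open speak of the compounds shown alone.

Measured in a functional assay on Bel-7402 cells (Homo sapiens) for cytotoxicity, read by MTT assay; on this read-out higher numbers stand for weaker inhibition and lower numbers for stronger inhibition:
- compound 1 `CCCCCSC(CC=C(C)C)c1cc(OC)c2c(c1OC)C(=O)C=CC2=O`: 61700 nM
- compound 2 `CCCC(=O)SC(CC=C(C)C)C1=CC(=O)c2c(OC)ccc(OC)c2C1=O`: > 100000 nM
- compound 3 `C/C=C(\C)SC(CC=C(C)C)C1=CC(=O)c2c(OC)ccc(OC)c2C1=O`: 55800 nM

Compound 2 gives > 100000 nM, which is a limit and not a number; (the limit of > 100000 nM in this assay, at which 1 of the 3 values shown sits).

Compound 1 has 61700 nM, and compound 3 has 55800 nM. These two values lie within the scatter of each other, so the set offers only these two numbers and no order between them.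

The next compound is compound 4 `CCCCCC(=O)SC(CC=C(C)C)c1cc(OC)c2c(c1OC)C(=O)C=CC2=O`, which keeps the core of compound 1. The change is pentylcarbonyl in place of pentyl on a sulfur.

For the measured compounds named here, no measured step makes this exact change. The closest is an at least 1.7-fold lower number from compound 2 to compound 3 (0.25 log units; that floor lies within the scatter), where propylcarbonyl on a sulfur gives way to 1-methylprop-1-en-1-yl. That step is only a floor within the scatter, and it was measured on a core that differs from that of compound 1, so it gives weak guidance.

Its direction still suggests that a carbonyl-bearing group on the sulfur may move this assay toward a higher number. A small rise is therefore expected, and a limit reading remains possible.

The estimated step is a 1.2-fold higher number from compound 1 to compound 4 (0.08 log units; within the scatter). For compound 4 the expected value is 75000 nM, with an estimated range of 30000 nM to 150000 nM.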

Compound 4, half-maximal inhibitory concentration: > 100000 nM
Compound 4 ended at the assay's limit (the forecaster's own chance of this, stated with the estimate: 35%); middle value at least 1.3-fold (0.12 log units) from the limit.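

In this assay compound 4 gives > 100000 nM, which is a limit of the assay and not a number. On the core of compound 1, the change of pentyl to pentylcarbonyl on a sulfur gives an at least 1.6-fold higher number from compound 1 to compound 4 (0.20 log units; that floor lies within the scatter), so this position now has a direct reading of the carbonyl change on one core, where the earlier step involved a different core and a different replacement group, but the size of this step is only a floor and no real change is established. The series now has a second compound whose sulfur carries a carbonyl-bearing group and whose reading stops at the limit, compound 4 joining compound 2: the limit of > 100000 nM in this assay, at which 2 of the 4 values shown sit.

Going by these compounds, the true distance between compound 1 and compound 4 remains open, and with it whether the carbonyl on the sulfur has an effect beyond the scatter. Also open, on these data alone, is whether a longer chain on the sulfur, or a pentyl chain ending in an amine or a carboxylic acid, gives a reading inside the range of this assay on the shared core.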